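Hydrogen in Place of Chloro: Estimating Compound 4

The source may hold more compounds than are shown below. What is called first, only, known or untested is meant among the compounds shown, and "the series" means these compounds.

The study compares three compounds in a functional assay on SW480 cells (Homo sapiens) for cytotoxicity, read by MTT assay, with a stated time of 72 h (a higher number here means a weaker inhibitor, a lower number a stronger inhibitor), and leaves a fourth to be measured. Compound 1, `Cc1cc(C)n2nc(SCc3cc(=O)c4cc(Cl)ccc4o3)nc2n1`, carries a chloro group on its core. In this assay compound 1 gives > 25000 nM, which is a limit of the assay rather than a number. Compound 3, `Nc1nnc(SCc2cc(=O)c3cc(Cl)ccc3o2)s1`, rests on a different core that also bears a chloro group. In this assay compound 3 gives > 25000 nM, again a limit and not a number. Compound 2, `Nc1nnc(SCc2cc(=O)c3ccccc3o2)s1`, is compound 3 with hydrogen in place of chloro on an aromatic carbon. In this assay compound 2 gives > 25000 nM, a limit as well. The step that the two limits leave unreadable from compound 3 to compound 2 therefore cannot be read in size, since (the limit of > 25000 nM in this assay, at which 3 of the 3 values shown sit). The difference between the core of compound 1 and the core of compound 3 is not broken down here.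

Compound 4, `Cc1cc(C)n2nc(SCc3cc(=O)c4ccccc4o3)nc2n1`, is not yet measured. It differs from compound 1 by hydrogen in place of chloro on an aromatic carbon, the same change that turns compound 3 into compound 2. Because (the limit of > 25000 nM in this assay, at which 3 of the 3 values shown sit), the expectation for compound 4 can rest only on the observation that every compound shown, with or without the chloro group, sits at that limit. Compound 4 is therefore expected to give about 35000 nM in this assay, most likely reported as a limit too. The step that the limit leaves unreadable from compound 1 to compound 4 is estimated to be small. The expected range for compound 4 is estimated to run from 10000 nM to 120000 nM.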

Compound 4, half-maximal inhibitory concentration: > 25000 nM
Compound 4: only a limit was reported; the forecaster's own chance of this, stated with the estimate: 85%; the middle value does not contradict the limit.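

In this assay compound 4 gives > 25000 nM as a limit of the assay and not a number. No step can be read from compound 1 to compound 4, since both compounds stand at a limit: the limit of > 25000 nM in this assay, at which 4 of the 4 values shown sit. The compounds shown leave open whether hydrogen in place of chloro on an aromatic carbon changes the value at all, on either core.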